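The source may report more compounds than this note shows. Statements on the series, on what has been measured and on what is new or still open speak of the compounds shown alone.

In an ADME assay on BJ cells (Homo sapiens) for cytotoxicity, read by CellTiter-Glo, with a stated time of 72 h (on this read-out lower numbers stand for an effect already at smaller amounts and higher numbers for an effect only at larger amounts of compound), two compounds sharing one core have been measured so far. Compound 1 `CC1=C2CC(C)(C)/C=C/[C@H](O)/C(C)=C\C3=C[C@H](C)C[C@]3(O2)C1=O` gives 10600 nM, and compound 2 `CC(=O)O[C@H]1/C=C/C(C)(C)CC2=C(C)C(=O)[C@]3(C[C@@H](C)C=C3/C=C\1C)O2` gives 26000 nM, the higher of the two numbers. Going by the values given here, the single measured step between them, acetyl in place of hydrogen on an oxygen on a saturated carbon, is a 2.5-fold higher number from compound 1 to compound 2 (0.39 log units; beyond the scatter), a modest change. Compound 3 `CC1=C2CC(C)(C)/C=C/[C@H](OC(=S)Sc3ccccc3)/C(C)=C\C3=C[C@H](C)C[C@]3(O2)C1=O` differs from compound 2 at that same oxygen: a group of 9 heavy atoms (7 carbon, 2 sulfur; one six-membered aromatic ring of carbon only) in place of a group of 3 heavy atoms (2 carbon, 1 oxygen; no ring), on an oxygen on a saturated carbon. The measured step bears on this change only in part, for it records a hydrogen being replaced on that oxygen, not one group giving way to a larger one. Among the compounds with values here, no measured compound carries an aromatic ring or sulfur at this place, so the data favour no direction. With only a 2.5-fold higher number from compound 1 to compound 2 (0.39 log units; beyond the scatter) as a guide, the oxygen stays substituted as in compound 2 at 26000 nM, and no step beyond the scatter is expected. The estimated change is a 1.2-fold lower number from compound 2 to compound 3 (0.07 log units; within the scatter). For compound 3 the estimate is 22000 nM, with the measurement expected between 7000 nM and 60000 nM.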

Compound 3, half-maximal effective concentration: 26000 nM
Compound 3: the middle estimate sits 1.2-fold (0.07 log units) below what was measured; measured number inside the range.
By their numbers in this assay, from the lowest: compound 1; then compounds 2 and 3 (each within the scatter of the next).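

In this assay, two very different groups on an oxygen on a saturated carbon now give the same reading: replacing acetyl with a group of 9 heavy atoms (7 carbon, 2 sulfur; one six-membered aromatic ring of carbon only) produces no change at the digits printed from compound 2 to compound 3 (within the scatter) and so leaves the number where it was. Replacing the hydrogen on that oxygen with the same larger group gives a 2.5-fold higher number from compound 1 to compound 3 (0.39 log units; beyond the scatter) in the same direction as the earlier acetyl step, so across these three compounds the number follows whether the oxygen carries a hydrogen or one of these two groups, while the choice between the two groups makes no visible difference. Nothing available gives a reason for this behaviour.

The compounds shown leave open whether this insensitivity extends to groups of another kind on the oxygen, such as a simple methyl ether, a longer alkyl chain, or a chain ending in an amine or a carboxylic acid. They also leave open what would happen if an amine took the place of the oxygen itself.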